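The compounds below may be only part of what the source reports. "The series", "measured", "known", "first", "only" and "open" are said of these compounds alone.

Compound 1 `NS(=O)(=O)c1cc(-c2nnc(CN3CCN(c4ccccc4)CC3)o2)c(Cl)cc1SCc1ccccc1` stands at the higher of the two numbers in a functional assay on HeLa cells (Homo sapiens) for cytotoxicity, read by MTT assay, with a stated time of 72 h (on this read-out higher numbers stand for weaker inhibition and lower numbers for stronger inhibition), giving 100000 nM; compound 2 `Cc1ccc(C)c(N2CCN(Cc3nnc(-c4cc(S(N)(=O)=O)c(SCc5ccccc5)cc4Cl)o3)CC2)c1` gives 16000 nM. Among the compounds with values here, the only measured step, a 6.3-fold lower number from compound 1 to compound 2 (0.80 log units; beyond the scatter), comes from 2,5-dimethylphenyl in place of phenyl on an amine nitrogen in a ring and leaves the rest of the shared core untouched. Compound 3 `CCOC(=O)c1cn(Cc2nnc(-c3cc(S(N)(=O)=O)c(SCc4ccccc4)cc3Cl)o2)nn1` differs from compound 1 by 4-(ethoxycarbonyl)-1H-1,2,3-triazol-1-yl in place of 4-phenylpiperazin-1-yl on a saturated chain carbon bound to an aromatic carbon. Within the data shown here, no measured step touches that part of the molecule, so the one step gives no direct guide; it shows only that numbers below compound 1 occur. Compound 3 is expected to give 60000 nM (range 15000 nM to 150000 nM), the estimated step of a 1.7-fold lower number from compound 1 to compound 3 (0.22 log units; within the scatter) resting on little support.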

Compound 3, half-maximal inhibitory concentration: 122000 nM
For compound 3 the middle estimate is 2.0-fold (0.31 log units) below the measured one; the range from low to high includes it.
By their numbers in this assay, from the lowest: compound 2; then compounds 1 and 3 (each within the scatter of the next).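

In this assay, the exchange of the whole 4-phenylpiperazin-1-yl group for 4-(ethoxycarbonyl)-1H-1,2,3-triazol-1-yl on the saturated chain carbon gives a 1.2-fold higher number from compound 1 to compound 3 (0.09 log units; within the scatter), a step within the scatter. The position therefore tolerates a different ring and a different set of hydrogen-bond acceptors with no separation of the two numbers, whereas the earlier step altered only the aryl group on the retained ring. Nothing on hand offers an explanation for this result.

Still open, from the compounds shown here alone, is whether a carboxylic acid in place of the ethoxycarbonyl group, or a morpholine at this carbon, would separate from compound 1.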